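Carboxy for (dimethylamino)methyl on the amide chain of compound 3

The compounds below may be only part of what the source reports. "The series", "measured", "known", "first", "only" and "open" are said of these compounds alone.

For the measured compounds named here, in a functional assay on MCF7 cells (Homo sapiens) for antiproliferative activity, read by MTT assay, with a stated time of 72 h (on this read-out lower numbers stand for stronger inhibition and higher numbers for weaker inhibition), compound 3 (`CCn1cc(C(CC)(CC)c2ccc(C#CC(O)(CC)CC)c(C)c2)cc1C(=O)NCCN(C)C`) gives 13400 nM, the only number in this small series. Compound 1 (`CCn1c(C(=O)On2nnc3ccccc32)ccc1C(CC)(CC)c1ccc(C#CC(O)(CC)CC)c(C)c1`) gives > 50000 nM, which is a limit of the assay and not a number. Compound 2 (`CCn1c(C(=O)NCCC(=O)O)ccc1C(CC)(CC)c1ccc(C#CC(O)(CC)CC)c(C)c1`) gives > 50000 nM, again a limit. The position of compound 3 therefore rests on thin evidence: the limit of > 50000 nM in this assay, at which 2 of the 3 values shown sit.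

The next change leads to compound 4 (`CCn1cc(C(CC)(CC)c2ccc(C#CC(O)(CC)CC)c(C)c2)cc1C(=O)NCC(=O)O`): carboxy in place of (dimethylamino)methyl on a saturated chain carbon bound to an amide-type nitrogen. In words, carboxy stands in place of (dimethylamino)methyl on a saturated chain carbon bound to an amide-type nitrogen.

Going by the values given here, the only measured step, a step that the two limits leave unreadable from compound 1 to compound 2, gives no size and so sets no scale for this change. The nearest guide is compound 2, which also carries a carboxy group on its amide chain and gives > 50000 nM, a limit. Its core is not arranged exactly as in compound 4, so the comparison is loose.

A weaker result is expected in this assay, probably close to the limit of the assay. The expected change is a 3.7-fold higher number from compound 3 to compound 4 (0.57 log units; beyond the scatter). For compound 4 the estimate is 50000 nM, with an expected range of 20000 nM to 100000 nM.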

Compound 4, half-maximal inhibitory concentration: 17500 nM
Estimate against measurement, compound 4: 2.9-fold (0.46 log units) above; the measured number lies below the stated range.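

In this assay, carboxy in place of (dimethylamino)methyl on a saturated chain carbon bound to an amide-type nitrogen gives a 1.3-fold higher number from compound 3 to compound 4 (0.12 log units; within the scatter), so this read-out does not separate the two groups at this place on the shared core. For the compounds shown here, this is the first step with a readable size, as the only earlier step runs between two limits and cannot be read. Compound 4 gives a number and not a limit, which brings the series to two numbers, but the limit remains a large part of the evidence: the limit of > 50000 nM in this assay, at which 2 of the 4 values shown sit.

The compounds shown leave open what a methyl ester or a primary amine on the same chain carbon would give in this assay, with the rest of the structure held constant. They also leave open whether the step from (dimethylamino)methyl to carboxy keeps its size on a longer chain, which would show whether the result belongs to this chain alone or holds more widely.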